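A few compounds are considered here, and "the series" means these few. Any claim that something is new, unique, unknown or untested is made for them only; others in the source may bear on it.

Measured so far:
compound 1 `CCCCNC1CC(C)C(O)C(O)C1O`: 920 nM
compound 2 `CC1CC(NCc2ccccc2)C(O)C(O)C1O`: 1000 nM
compound 3 `CCCCNC1=NC2CC(C)C(O)C(O)C2O1`: 140000 nM

All three were run in an assay on isolated protein (Bos taurus) for inhibition of tissue alpha-L-fucosidase (Homo sapiens); a lower number here means a stronger inhibitor, a higher number a weaker inhibitor. Compound 3 gives the highest number of the three, beyond the scatter from both compound 1 and compound 2. The difference between the core of compound 3 and the core of compound 1 is not broken down here. Between the two first compounds the change is phenyl in place of propyl on a saturated chain carbon bound to an amine nitrogen, and it gave a 1.1-fold higher number from compound 1 to compound 2 (0.04 log units; within the scatter).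

Compound 4 `CC1CC2N=C(NCc3ccccc3)OC2C(O)C1O` is not yet measured. Relative to compound 3 it carries the same change, at the same place: phenyl in place of propyl on a saturated chain carbon bound to an amine nitrogen. Within the data shown here, for compound 4 the expected step is a 1.1-fold higher number from compound 3 to compound 4 (0.03 log units; within the scatter), because the only measured instance of this change gave a 1.1-fold higher number from compound 1 to compound 2 (0.04 log units; within the scatter). Compound 4 is therefore expected to stay close to compound 3 in this assay, estimated at 150000 nM, most likely between 60000 nM and 400000 nM.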

Compound 4, half-maximal inhibitory concentration: 72000 nM
Compound 4: the middle estimate sits 2.1-fold (0.32 log units) above what was measured; measured number inside the range.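

In this assay, phenyl in place of propyl on a saturated chain carbon bound to an amine nitrogen gives a 1.9-fold lower number from compound 3 to compound 4 (0.29 log units; within the scatter), so on this second core the change again produces no step beyond the scatter. The two instances of the change cannot be told apart, so within this pair of cores it carries over with no measurable difference: the same change on two cores in this assay, a 1.1-fold higher number (0.04 log units; within the scatter) from compound 1 to compound 2 and a 1.9-fold lower number (0.29 log units; within the scatter) from compound 3 to compound 4, 2.1-fold (0.33 log units) apart, within the scatter of two such steps. This rests on two pairs only and shows that the change is neutral on these two cores, not that it would be neutral on any other core in the series.

Open, as far as these compounds go, is whether a longer chain or a carboxylic acid in place of propyl would shift the result on either core. Also open, from the compounds shown here alone, is which feature of the core of compound 3 separates it from the core of compound 1.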